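A few compounds are considered here, and "the series" means these few. Any claim that something is new, unique, unknown or untested is made for them only; others in the source may bear on it.

Measured so far in a functional assay on KG-1 cells (Homo sapiens) for antiproliferative activity, read by CCK-8 assay, with a stated time of 72 h; a higher number here means a weaker inhibitor, a lower number a stronger inhibitor:
Compound 1 `CCN1CCN(c2ccc(C(=O)Nc3n[nH]c4cc(-c5c(F)cc(F)c(OC)c5F)ccc34)cc2)CC1` gives > 1000 nM, which is a limit of the assay rather than a number.
Compound 2 `CCN1CCN(c2ccc(C(=O)Nc3n[nH]c4cc(-c5cccc(OC)c5F)ccc34)cc2C(F)(F)F)CC1` gives > 1000 nM, also a limit.

Among the measured compounds shown here, compound 1 therefore stands at the edge of what this assay reports, and the only other value shown is a limit too, so no measured step sets a scale here. the limit of > 1000 nM in this assay, at which 2 of the 2 values shown sit, describes where both values sit. Compound 3 `CCN1CCN(c2ccc(C(=O)Nc3n[nH]c4cc(-c5c(F)ccc(OC)c5F)ccc34)cc2)CC1` differs from compound 1 by hydrogen in place of fluoro on an aromatic carbon. With nothing measured to follow, the expected step that the limit leaves unreadable from compound 1 to compound 3 is small, none beyond the scatter, in no firm direction. Compound 3 is expected to give about 1500 nM, within 500 nM to 5000 nM.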

Compound 3, half-maximal inhibitory concentration: 25.3 nM
For compound 3 the middle estimate is 59-fold (1.77 log units) above the measured one; the measured number lies below the stated range.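

In this assay there is an at least 39-fold lower number from compound 1 to compound 3 (1.59 log units; beyond the scatter) when one fluoro gives way to hydrogen, turning 2,4,6-trifluoro-3-methoxyphenyl into 2,6-difluoro-3-methoxyphenyl. This position, ortho to a methoxy group, is therefore far from silent: this single change moves a compound from the limit of the assay to a measured value. The step's true size stays a bound, because one end of it is a limit and not a number: the limit of > 1000 nM in this assay, at which 2 of the 3 values shown sit.

The compounds shown leave open whether only fluoro has this effect here, or whether a chloro or methyl group at this position would do the same.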